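Replacing the sulfamoyl group of compound 3

A few compounds are considered here, and "the series" means these few. Any claim that something is new, unique, unknown or untested is made for them only; others in the source may bear on it.

In an ADME assay (liver) for metabolic stability, with Liver microsome (Rattus norvegicus) as the target, using microsomes and NADPH, with a stated time of 30 min (a lower number here means slower removal, a higher number faster removal of the compound), compound 1 `CC#C[C@H]1CN(S(=O)(=O)c2ccc(N)nc2)CCN1c1ccc([C@@](O)(CO)C(F)(F)F)cc1` gives 53 mL.min-1.g-1. Compound 2 `CC#C[C@H]1CN(S(=O)(=O)c2ccc(N)nc2)CCN1c1ccc(S(=O)(=O)Nc2ccccc2)cc1` gives > 399 mL.min-1.g-1, which is a limit of the assay and not a number. Compound 3 `CC#C[C@H]1CN(S(=O)(=O)c2ccc(N)nc2)CCN1c1ccc(S(=O)(=O)NCC2CC2)cc1` gives 213 mL.min-1.g-1, the higher of the two true numbers in the series.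

Two measured steps go beyond the scatter: a 4.0-fold higher number from compound 1 to compound 3 (0.60 log units; beyond the scatter) and an at least 7.5-fold higher number from compound 1 to compound 2 (0.87 log units; beyond the scatter). The floor of the third, an at least 1.8-fold lower number from compound 2 to compound 3 (0.27 log units; that floor lies within the scatter), lies within the scatter, so that step fixes no size.

Compound 4 `CC#C[C@H]1CN(S(=O)(=O)c2ccc(N)nc2)CCN1c1ccc(C(O)(CC#N)C(F)(F)F)cc1` is compound 3 with one change, on an aromatic carbon of a six-membered aromatic ring of carbon only, para to a large group: a group of 9 heavy atoms (4 carbon, 1 nitrogen, 1 oxygen, 3 fluorine; no ring) in place of a group of 8 heavy atoms (4 carbon, 1 nitrogen, 2 oxygen, 1 sulfur; one three-membered non-aromatic ring of carbon only), on an aromatic carbon. The (cyclopropylmethyl)sulfamoyl group leaves, and the group that enters has fluorine, no sulfur and no ring, as does the group on compound 1.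

The closest guide is therefore a 4.0-fold higher number from compound 1 to compound 3 (0.60 log units; beyond the scatter), a step that runs the opposite way and exchanges the same sulfamoyl group for a group of that kind. Most of that modest step should be undone, though the nitrile-bearing chain of compound 4 has not been measured against compound 1. The expected change in this assay is a decrease beyond the scatter, estimated as a 2.7-fold lower number from compound 3 to compound 4 (0.43 log units; beyond the scatter). For compound 4 the expected value is 80 mL.min-1.g-1, with an estimated range from 35 mL.min-1.g-1 to 190 mL.min-1.g-1.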

Compound 4, intrinsic clearance in microsomes: 57 mL.min-1.g-1
Compound 4: middle estimate off by 1.4-fold (0.15 log units), on the high side; the range from low to high includes it.
By their numbers in this assay, from the lowest: compounds 1 and 4 (each within the scatter of the next); then compound 3. At a limit, above all of these: compound 2.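

In this assay, exchanging the (cyclopropylmethyl)sulfamoyl group for a chain with fluorine, a nitrile and no sulfur gives a 3.7-fold lower number from compound 3 to compound 4 (0.57 log units; beyond the scatter) and so provides a direct reading of this change on an aromatic carbon, para to a large group. Set against the group on compound 1, the nitrile-bearing chain gives a 1.1-fold higher number from compound 1 to compound 4 (0.03 log units; within the scatter) and the two groups without sulfur cannot be told apart here, although only the group on compound 4 carries a nitrile. Compound 2 stands at a limit and not a number, which leaves only a floor for the exchange of its phenyl sulfonamide for the nitrile-bearing chain, read as an at least 7.0-fold lower number from compound 2 to compound 4 (0.84 log units; beyond the scatter) and fixing no size: the limit of > 399 mL.min-1.g-1 in this assay, at which 1 of the 4 values shown sits.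

On these data alone, it remains open whether a primary amide or a carboxylic acid in place of the nitrile, or a longer chain at the same place, would stay within the scatter of compound 1 and compound 4. As far as these compounds go, all four compounds share one core and the same group on the other sulfonyl, so whether the step to compound 4 carries over to a different amine on that sulfonyl also remains open.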